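The source may hold more compounds than are shown below. What is called first, only, known or untested is meant among the compounds shown, and "the series" means these compounds.

The study measures how much of each compound MT2 cells tolerate in a functional assay on MT2 cells (Homo sapiens) for cytotoxicity, read by MTT assay; a higher number here means that more compound is tolerated, a lower number that less compound is tolerated. Compound 1 `CC(C)=CCOc1cc(Nc2nccs2)ccc1C` gives 17000 nM in this assay, and compound 2 `CC(C)=CCOc1cc(Nc2nccs2)ccc1Cl` gives 26000 nM. The two differ by methyl in place of chloro on an aromatic carbon, and this step, a 1.5-fold lower number from compound 2 to compound 1 (0.18 log units; within the scatter), lies within the scatter. Compound 3 `COc1ccnc(Nc2ccc(Cl)c(OCC=C(C)C)c2)n1` carries a different core; how its core differs from that of compound 2 is not broken down here. In this assay compound 3 gives 9000 nM, a number within the scatter of compound 1 and beyond the scatter of compound 2.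

Compound 4 `COc1ccnc(Nc2ccc(C)c(OCC=C(C)C)c2)n1` is not yet measured. It differs from compound 3 by methyl in place of chloro on an aromatic carbon. Around the place the two changes differ in what stands para: a (1,3-thiazol-2-yl)amino group in the pair of compound 2 and compound 1, a group of 9 heavy atoms in the pair of compound 3 and compound 4, so this is the same kind of change rather than the same change. Compound 4 is expected to show a step of a 1.3-fold lower number from compound 3 to compound 4 (0.11 log units; within the scatter), resting on the small step of a 1.5-fold lower number from compound 2 to compound 1 (0.18 log units; within the scatter). The estimate for compound 4 is therefore 7000 nM, between 3500 nM and 14000 nM.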

Compound 4, half-maximal cytotoxic concentration: 41000 nM
The estimate for compound 4 lay 5.9-fold (0.77 log units) below the measured number; the whole stated range lies below it.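

On the core of compound 3, methyl in place of chloro on an aromatic carbon gives a 4.6-fold higher number from compound 3 to compound 4 (0.66 log units; beyond the scatter) in this assay, so more compound is tolerated with the methyl group on this core. These two pairs do not show which feature of the cores accounts for the difference, nor how the change would behave on any further core. What they do show is that the result of this change on one core cannot simply be carried over to the other in this series: the same change on two cores in this assay, a 1.5-fold lower number (0.18 log units; within the scatter) from compound 2 to compound 1 and a 4.6-fold higher number (0.66 log units; beyond the scatter) from compound 3 to compound 4, 7.0-fold (0.84 log units) apart, beyond the scatter of two such steps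

The compounds shown carry only chloro or methyl at this place, so it remains open how fluoro, methoxy or a nitrile would behave there on either core. All of them also keep the (3-methylbut-2-en-1-yl)oxy group, which leaves open whether the gap between the two cores would persist with a shorter chain such as ethoxy in its stead.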